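The compounds below may be only part of what the source reports. "The series", "measured", "known", "first", "only" and "open" are said of these compounds alone.

Measured compounds in a functional assay on A549 cells (Homo sapiens) for cytotoxicity, read by MTT assay, with a stated time of 72 h; on this read-out lower numbers stand for stronger inhibition and higher numbers for weaker inhibition:
compound 1 `COc1cc2c(Oc3ccc(NC(=O)c4cn(-c5ccccc5F)nn4)cc3F)ccnc2cc1OCCCN1CCCCC1` gives 2770 nM
compound 2 `COc1cc2c(Oc3ccc(NC(=O)c4cn(-c5ccc(Br)cc5)nn4)cc3F)ccnc2cc1OCCCN1CCCCC1` gives 230 nM
compound 3 `COc1cc2c(Oc3ccc(NC(=O)c4cn(-c5c(C)cccc5C)nn4)cc3F)ccnc2cc1OCCCN1CCCCC1` gives "not determined" (no result reported)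

Compound 3 stands without a number in this assay; nothing is known of its own potency. Compound 4 `COc1cc2c(Oc3ccc(NC(=O)c4cn(-c5c(Cl)cccc5Cl)nn4)cc3F)ccnc2cc1OCCCN1CCCCC1` differs from it only in 2,6-dichlorophenyl in place of 2,6-dimethylphenyl on an aromatic nitrogen. Going by the values given here, the one measured step, a 12-fold lower number from compound 1 to compound 2 (1.08 log units; beyond the scatter), changes the same phenyl group on the aromatic nitrogen, but swaps a fluorine-bearing ring for a bromine-bearing one at a different substitution pattern, so it does not describe the dimethyl-to-dichloro exchange. Among the compounds with values here, no step bears directly on the change from compound 3 to compound 4, and the absent value for compound 3 leaves no anchor. The estimate for compound 4 therefore rests on the spread of compounds 1 and 2 alone: compound 4 is expected at about 1000 nM, within 200 nM to 5000 nM.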

Compound 4, half-maximal inhibitory concentration: 150 nM
The estimate for compound 4 lay 6.7-fold (0.82 log units) above the measured number; the measured number lies below the stated range.
By their numbers in this assay, from the lowest: compounds 4 and 2 (each within the scatter of the next); then compound 1.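

On the aromatic nitrogen, 2,6-dichlorophenyl and 4-bromophenyl cannot be told apart, with a 1.5-fold lower number from compound 2 to compound 4 (0.19 log units; within the scatter), whereas 2,6-dichlorophenyl in place of 2-fluorophenyl gives an 18-fold lower number from compound 1 to compound 4 (1.27 log units; beyond the scatter). The large gap seen earlier is therefore not tied to 4-bromophenyl alone, as a second halogen-bearing phenyl group now also stands clear of compound 1. No evidence on the cause of these differences is at hand.

Compound 3 has no number, so the exchange of 2,6-dimethylphenyl for 2,6-dichlorophenyl cannot be read. On these data alone, how a phenyl group carrying an amine or a carboxylic acid would fare at this position remains open.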